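Macrocycle-linked anilinoquinazoline series: bromo to cyano exchange

This account rests on a few compounds, and the source may have more. Where it says the series, first, only, none or still open, it means among the compounds named here.

Measured compounds:
Compound 1 `COc1cc2ncnc(Nc3ccc(Br)cc3F)c2cc1OCCCN1CCNCCNCCNCC1`: 1840 nM
Compound 2 `COc1cc2ncnc(Nc3ccc(Cl)cc3Cl)c2cc1OCCCN1CCNCCNCCNCC1`: 4390 nM
Compound 3 `COc1cc2ncnc(Nc3ccc(Br)cc3F)c2cc1OCCCN1CCNCCNCC1`: 561 nM

In a functional assay on A-431 cells (Homo sapiens) for antiproliferative activity, read by MTT assay, with a stated time of 72 h (a lower number here means a stronger inhibitor, a higher number a weaker inhibitor), compound 3 gives the lowest number of the three, with compound 1 the nearest at a higher number and compound 2 the furthest. Compound 4 `COc1cc2ncnc(Nc3ccc(C#N)cc3F)c2cc1OCCCN1CCNCCNCC1` is the next member and is not yet measured. It differs from compound 3 by cyano in place of bromo on an aromatic carbon; the same difference, cut one bond further out, reads 4-bromo-2-fluorophenyl to 4-cyano-2-fluorophenyl.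

Of the measured steps only a 2.4-fold higher number from compound 1 to compound 2 (0.38 log units; beyond the scatter) touches the aromatic ring that carries the change, and that step is modest. The other step, a 3.3-fold lower number from compound 1 to compound 3 (0.52 log units; beyond the scatter), concerns the ring on the saturated chain and does not bear on this exchange. Among the measured compounds shown here, no measured pair swaps bromo for cyano, so the direction is open; a modest step, likely toward a somewhat higher number, is expected, a 2.1-fold higher number from compound 3 to compound 4 (0.33 log units; beyond the scatter).

Compound 4 is therefore expected to give about 1200 nM in this assay, with a range from 400 nM to 3600 nM.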

Compound 4, half-maximal inhibitory concentration: 12700 nM
Compound 4: the middle estimate sits 11-fold (1.02 log units) below what was measured, and the stated range ends below it.
By their numbers in this assay, from the lowest: compound 3; then compound 1; then compound 2; then compound 4.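

In this assay, the aromatic carbon para to a large group proves highly sensitive to the group it carries: with the nine-membered ring and the fluoro group held constant, cyano in place of bromo gives a 23-fold higher number from compound 3 to compound 4 (1.35 log units; beyond the scatter). Among the compounds shown here, this step is classed as large, whereas a 2.4-fold higher number from compound 1 to compound 2 (0.38 log units; beyond the scatter), the only earlier change on this aromatic ring, is classed as modest and altered both substituents of the ring together. The data offer no measured basis for explaining the size of the new step.

The compounds shown leave open whether chloro, methyl or an amine at this carbon would stay close to bromo or move towards cyano. They also leave open whether the same exchange would give a step of similar size with the larger ring of compound 1.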